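A Bromine Swap at the Limit of the Assay

The compounds below may be only part of what the source reports. "The series", "measured", "known", "first", "only" and "open" are said of these compounds alone.

In a functional assay on MCF7 cells (Homo sapiens) for antiproliferative activity, read by MTT assay, with a stated time of 48 h (a higher number here means a weaker inhibitor, a lower number a stronger inhibitor), compound 2 `O=C(CN1CCCCC1)Nc1ccc2ncnc(Nc3ccc(Cl)cc3)c2c1` gives > 100000 nM, which is a limit and not a number. Compound 1 `O=C(CN1CCCCC1)Nc1ccc2ncnc(Nc3cccc(Cl)c3)c2c1` gives > 100000 nM, which is also a limit. The starting point is therefore (the limit of > 100000 nM in this assay, at which 2 of the 3 values shown sit).

Among the measured compounds shown here, compound 4 `O=C(CN1CCCCC1)Nc1ccc2ncnc(Nc3cccc(Br)c3)c2c1` changes only one group of compound 2: 3-bromophenyl in place of 4-chlorophenyl on a nitrogen on an aromatic ring. In words, this is 3-bromophenyl in place of 4-chlorophenyl on a nitrogen on an aromatic ring.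

For the measured compounds named here, two measured steps bear on this change. The closest one, on the same nitrogen, is a step that the two limits leave unreadable from compound 1 to compound 2, so it gives no size to build on. Going by the values given here, the only readable step is an at least 6.6-fold lower number from compound 2 to compound 3 (0.82 log units; beyond the scatter), which brings compound 3 `CN1CCN(CC(=O)Nc2ccc3ncnc(Nc4ccc(Cl)cc4)c3c2)CC1` to 15000 nM. That step comes from 4-methylpiperazin-1-yl in place of piperidin-1-yl, and compound 4 keeps the piperidin-1-yl, so this gain is not expected to carry over.

A result near the limit is expected for compound 4 because compound 1 gives > 100000 nM, and compound 1 also carries the piperidin-1-yl and a halogen-bearing phenyl group on that nitrogen. No step beyond the scatter is expected in this assay, and the estimated step is a number no higher from compound 2 to compound 4 (the limit leaves the size open). For compound 4 the expected value is 100000 nM, with an estimated range of 30000 nM to 200000 nM.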

Compound 4, half-maximal inhibitory concentration: 3000 nM
For compound 4 the middle estimate is 33-fold (1.52 log units) above the measured one, and the stated range ends above it.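

The clearest comparison here is bromo in place of chloro on an aromatic carbon, which gives an at least 33-fold lower number from compound 1 to compound 4 (1.52 log units; beyond the scatter), so in this assay a single halogen swap is enough to produce a readable value while the piperidin-1-yl stays in place. The other step, an at least 33-fold lower number from compound 2 to compound 4 (1.52 log units; beyond the scatter), changes both the halogen and its place on the phenyl group, so on its own it cannot separate the two changes, whereas the comparison with the 3-chlorophenyl of compound 1 keeps the place fixed and points to the halogen. Until now, only the step at the 4-methylpiperazin-1-yl had given a readable value, and these results add the group on the nitrogen as a second place that matters, with both new steps being minimum sizes that rest on the assay limit shared by compound 1 and compound 2: the limit of > 100000 nM in this assay, at which 2 of the 4 values shown sit.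

Still open, from the compounds shown here alone, is whether a 4-bromophenyl group would behave like the 3-bromophenyl group, which would show how much the place of the bromine counts. Also open, going by these compounds, are whether iodo or methyl at that place would give a similar step, and whether the 3-bromophenyl group and the 4-methylpiperazin-1-yl together would add up.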